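Replacing a Hydroxyl Hydrogen with Isopropyl

The compounds below may be only part of what the source reports. "The series", "measured", "known", "first", "only" and "open" are said of these compounds alone.

Three measured compounds share one core. Compound 1 `Oc1ccccc1CNc1ccc(-c2ccc(C(F)(F)F)cc2)cc1` is reported as "not active" (no number reported) in a functional assay on Jurkat cells (Homo sapiens) for activation, with a stated time of 24 h (a higher number here means that more compound is needed for the effect, a lower number that less compound is needed), with no number given. Compound 2 `COc1ccc(-c2ccc(NCc3ccccc3O)cc2)cc1` gives 580 nM in this assay. Going by the values given here, compound 3 `Oc1ccc(-c2ccc(NCc3ccccc3O)cc2)cc1` is also reported as "not active" (no number reported) in this assay, so no single number stands for it and no measured step starts from it. Compound 4 `CC(C)Oc1ccc(-c2ccc(NCc3ccccc3O)cc2)cc1` carries the change (isopropyl in place of hydrogen on an oxygen on an aromatic ring). Among the compounds with values here, no measured pair shows this exact change, so its size cannot be read from the data. Because compound 2 gives 580 nM while compound 3 gives no number, a measurable value is expected for compound 4, though with wide uncertainty. Compound 4 is expected to give about 1500 nM, within 300 nM to 8000 nM.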

Compound 4, half-maximal effective concentration: 5940 nM
For compound 4 the middle estimate is 4.0-fold (0.60 log units) below the measured one; low and high end bracket the measured number.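

In this assay, the size of the group on this oxygen matters: isopropyl in place of methyl gives a 10-fold higher number from compound 2 to compound 4 (1.01 log units; beyond the scatter). Hydroxy to isopropoxy cannot be read as a step, since compound 3 is "not active" (no number reported) and has no number. The isopropoxy compound 4 still gives a measurable 5940 nM, so this oxygen can carry a group larger than methyl with activity remaining. The compounds shown leave open how an ethyl group or a longer chain on this oxygen would read. No measurement shown here explains the change in value.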